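Swapping a Chlorophenyl Ring for Thiophene in a Thiosemicarbazone

The compounds below may be only part of what the source reports. "The series", "measured", "known", "first", "only" and "open" are said of these compounds alone.

Compound 1 `CC1=CC[C@H](C(C)(C)NC(=S)NN)CC1`, compound 2 `CC1=CC[C@H](C(C)(C)NC(=S)N/N=C/c2ccc(F)cc2)CC1`, compound 3 `CC1=CC[C@H](C(C)(C)NC(=S)N/N=C/c2ccccc2Cl)CC1` and the still unmeasured compound 4 `CC1=CC[C@H](C(C)(C)NC(=S)N/N=C/c2cccs2)CC1` share one core. In a functional assay on HT-29 cells (Homo sapiens) for inhibition, read by sulforhodamine B assay, with a stated time of 48 h (a lower number here means a stronger inhibitor of growth, a higher number a weaker inhibitor of growth), compound 1 gives 60100 nM. Compound 2 reaches the assay limit, > 100000 nM, which is a limit and not a number (the limit of > 100000 nM in this assay, at which 1 of the 3 values shown sits). In this assay compound 3 gives 71300 nM, the higher of the two numbers shown, though its gap to compound 1 lies within the scatter. Going by the values given here, the one measured step, an at least 1.4-fold lower number from compound 2 to compound 3 (0.14 log units; that floor lies within the scatter), is small. Compound 4 differs from compound 3 by thiophen-2-yl in place of 2-chlorophenyl on a carbon with a double bond to nitrogen. Among the compounds with values here, no measured step covers this exchange, and the single step seen stays within the scatter, so no shift beyond the scatter is expected. Compound 4 is therefore estimated at 70000 nM, between 30000 nM and 160000 nM, an expected step of a 1.0-fold lower number from compound 3 to compound 4 (0.01 log units; within the scatter).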

Compound 4, concentration for 50% growth inhibition: 17800 nM
Compound 4: the middle estimate sits 3.9-fold (0.59 log units) above what was measured; the measured number lies below the stated range.
By their numbers in this assay, from the lowest: compound 4; then compounds 1 and 3 (each within the scatter of the next). At a limit, above all of these: compound 2.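

In this assay, the ring on the carbon with a double bond to nitrogen now makes a clear difference: the exchange brings a 4.0-fold lower number from compound 3 to compound 4 (0.60 log units; beyond the scatter), whereas the earlier step between rings stayed within the scatter. Thiophen-2-yl also separates from the core carrying no ring, with a 3.4-fold lower number from compound 1 to compound 4 (0.53 log units; beyond the scatter), and the comparison with the fluorinated ring gives an at least 5.6-fold lower number from compound 2 to compound 4 (0.74 log units; beyond the scatter). That last step is only a floor, as compound 2 stands at a limit and not at a number: the limit of > 100000 nM in this assay, at which 1 of the 4 values shown sits.

As far as these compounds go, whether the change depends on the sulfur atom or on the five-membered ring stays open. A furan-2-yl or pyridin-2-yl group at this position would help separate the two.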